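The source may hold more compounds than are shown below. What is called first, only, known or untested is meant among the compounds shown, and "the series" means these compounds.

The compounds measured in a functional assay on NCI-H460 cells (Homo sapiens) for cytotoxicity, read by MTT assay, with a stated time of 48 h (on this read-out higher numbers stand for weaker inhibition and lower numbers for stronger inhibition), are these:

Compound 1 `C=C1C(=O)O[C@H]2CC3=C[C@H](C/C(C)=C/[C@@H](OC(=O)c4ccc([N+](=O)[O-])cc4)[C@H]12)OC3=O` gives > 10000 nM, which is a limit of the assay and not a number.
Compound 2 `C=C1C(=O)O[C@H]2CC3=C[C@H](C/C(C)=C/[C@@H](OC(=O)CCCCBr)[C@H]12)OC3=O` gives > 10000 nM, again a limit rather than a number.
Compound 3 `C=C1C(=O)O[C@H]2CC3=C[C@H](C/C(C)=C/[C@@H](OC(=O)CCl)[C@H]12)OC3=O` gives > 10000 nM, also a limit.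

Compound 1 therefore stands at the limit itself, and nothing in the numbers ranks it against the other two. All three share one core and differ only in the group carried on the carbonyl carbon of the ester. Exchanging these groups yields a step that the two limits leave unreadable from compound 1 to compound 2, a step that the two limits leave unreadable from compound 1 to compound 3 and a step that the two limits leave unreadable from compound 2 to compound 3, so none of the three exchanges can be sized. The one thing the data show is the limit of > 10000 nM in this assay, at which 3 of the 3 values shown sit.

Compound 4 `C=C1C(=O)O[C@H]2CC3=C[C@H](C/C(C)=C/[C@@H](OC(=O)C4CCC(F)(F)CC4)[C@H]12)OC3=O` has not yet been measured in this assay. It differs from compound 1 by 4,4-difluorocyclohexyl in place of 4-nitrophenyl on a carbonyl carbon. Going by the values given here, the steps that bear on this change are the three above, each of them unreadable for the same reason, so they give no direction and no size. What they do suggest is that changing this ester group has not moved any compound away from the limit so far.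

On that basis compound 4 is expected to give 15000 nM, within 5000 nM to 50000 nM. The expected step in this assay is a step that the limit leaves unreadable from compound 1 to compound 4, most likely ending again at a limit.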

Compound 4, half-maximal inhibitory concentration: > 10000 nM
Compound 4: no number, only a limit (the forecaster's own chance of this, stated with the estimate: 75%); the middle value is on the limit's open side.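

In this assay compound 4 gives > 10000 nM, which is a limit and not a number. The steps to compound 4 from compound 1, compound 2 and compound 3 therefore cannot be read, and the four compounds stay unranked: the limit of > 10000 nM in this assay, at which 4 of the 4 values shown sit. The compounds shown leave open whether any ester group on the shared core gives a measurable value in this assay.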